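A few compounds are considered here, and "the series" means these few. Any claim that something is new, unique, unknown or untested is made for them only; others in the source may bear on it.

Measured so far:
- compound 1, `COc1cc2c(Oc3ccc(NC(=O)c4cn(-c5ccc(Cl)cc5)cn4)cc3F)ccnc2cc1OCCCN1CCN(C)CC1`, 1350 nM
- compound 2, `COc1cc2c(Oc3ccc(NC(=O)c4cn(-c5ccc(Cl)cc5Cl)cn4)cc3F)ccnc2cc1OCCCN1CCCCC1`, 4300 nM
- compound 3, `COc1cc2c(Oc3ccc(NC(=O)/C=C/S(=O)(=O)c4ccccc4F)cc3F)ccnc2cc1OCCCN1CCN(C)CC1`, 150 nM

In a functional assay on HT-29 cells (Homo sapiens) for cytotoxicity, read by MTT assay, with a stated time of 72 h (a higher number here means a weaker inhibitor, a lower number a stronger inhibitor), compound 3 gives the lowest number of the three; the nearest is compound 1, and the furthest is compound 2. Among the compounds with values here, the one step measured between compounds that differ in a single place is a 9.0-fold lower number from compound 1 to compound 3 (0.95 log units; beyond the scatter), which swaps the whole group on the carbonyl carbon. Compounds 1 and 2 differ in two places at once, so their two values only show that both sit well above compound 3 in this assay.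

Compound 4, `COc1ccc(S(=O)(=O)/C=C/C(=O)Nc2ccc(Oc3ccnc4cc(OCCCN5CCN(C)CC5)c(OC)cc34)c(F)c2)cc1`, keeps everything of compound 3 except the ring on the sulfonyl sulfur: 4-methoxyphenyl in place of 2-fluorophenyl on a sulfonyl sulfur. Within the data shown here, no measured step touches the ring on that sulfur; the step from compound 1 to compound 3 changes a different part of the molecule and says nothing about how the aryl on the sulfonyl may be varied. Among the measured compounds shown here, with no precedent in the data, a change within the scatter is the expectation for compound 4, in either direction, and the estimate is written as a 1.3-fold higher number from compound 3 to compound 4 (0.12 log units; within the scatter). For compound 4 in this assay the expected value is 200 nM, with a range from 60 nM to 650 nM.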

Compound 4, half-maximal inhibitory concentration: 1660 nM
Beside the measured number, compound 4's estimate is 8.3-fold (0.92 log units) below it, outside the stated range (above it).
By their numbers in this assay, from the lowest: compound 3; then compounds 1 and 4 (each within the scatter of the next); then compound 2.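

The aryl on the sulfonyl sulfur proves to be a sensitive position in this assay: 4-methoxyphenyl in place of 2-fluorophenyl gives an 11-fold higher number from compound 3 to compound 4 (1.04 log units; beyond the scatter) and so takes away most of what set compound 3 apart. Within the data shown here, until now the only step that could be read lay on the carbonyl carbon, where the whole group was exchanged, and it left open whether the sulfonyl-bearing chain alone could account for the low number of compound 3; this pair shows that it cannot, since that number depends on which aryl the sulfonyl carries, and only compound 3 and compound 4 speak to this. Among these compounds, nothing available explains why this exchange moves the number so far.

From the compounds shown here alone, this single step removes the fluorine and brings in the methoxy at once, so it remains open which of the two carries the change. A plain phenyl, a 4-fluorophenyl or a 2-methoxyphenyl on the sulfonyl sulfur would separate them, and a pyridyl or a small alkyl such as methyl there would show how far the position tolerates losing the benzene ring altogether.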